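5-Methylfuran Out, Pyridine In: One Change, One Expectation

The compounds below may be only part of what the source reports. "The series", "measured", "known", "first", "only" and "open" are said of these compounds alone.

Measured so far:
Compound 1, `Cc1ccc(-c2nc(CNc3ccc(C(=O)NO)cc3)n(-c3ccccc3)n2)o1`: 60.7%
Compound 2, `O=C(NO)c1ccc(NCc2nc(-c3ccccc3)nn2-c2ccccc2Cl)cc1`: 64.6%

Both compounds were tested in an assay on Sf9 cells for inhibition of protein deacetylase HDAC6 (Homo sapiens), read by fluorescence, with a stated time of 40 min, tested at 100 nM; a lower number here means less inhibition, a higher number more inhibition at the concentration tested (going by the name of the read-out). Compound 1 stands lowest of the two numbers, but its nearest neighbour, compound 2, lies within the usual scatter of it, so the two cannot be ranked against each other.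

Compound 3, `O=C(NO)c1ccc(NCc2nc(-c3cccnc3)nn2-c2ccccc2)cc1`, has not yet been measured. It differs from compound 1 in one place: pyridin-3-yl in place of 5-methylfuran-2-yl on an aromatic carbon. A six-membered aromatic ring thus takes the place of a five-membered one on an aromatic carbon of the shared core, with no change in charge.

Within the data shown here, no two measured compounds differ in a single place, so the data offer no measured step of this kind to lean on. What they do show is that two compounds differing in several places still sit within the scatter of each other. The expected step of a number 2.7 percentage points lower from compound 1 to compound 3 (within the scatter) is therefore small, no larger than the scatter and of no certain direction. Compound 3 is estimated at 58%, with a range from 40% to 75%.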

Compound 3, a percentage reported as inhibition, at one concentration (the size of the read-out at that concentration, not a potency): 57.7%
For compound 3 the middle estimate is 0.3 percentage points above the measured one, and the stated range covers the measured number.
By their numbers in this assay, from the lowest: compounds 3, 1 and 2 (each within the scatter of the next).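

In this assay, among these compounds, the change from 5-methylfuran-2-yl to pyridin-3-yl gives the first reading of a single change at this position, on an aromatic carbon of the five-membered aromatic ring with 3 nitrogen: a number 3 percentage points lower from compound 1 to compound 3 (within the scatter). The two groups match in heavy atoms, hydrogen-bond donors and acceptors, and neither carries a net charge, but they differ in ring size and in their hetero atom, oxygen in one and nitrogen in the other. For this pair, that swap of rings does not move the read-out beyond the usual scatter at the single concentration tested, and no measurement is at hand that could say what lies behind this result.

Both groups at this position are aromatic rings, so the compounds shown leave open how the read-out would respond to a morpholine, a carboxylic acid or a longer alkyl chain in the same place. They also leave open whether moving the ring nitrogen, as in pyridin-4-yl, would matter, and whether compound 1 and compound 3 would still look alike in a full potency measurement across several concentrations.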